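This account rests on a few compounds, and the source may have more. Where it says the series, first, only, none or still open, it means among the compounds named here.

Measured so far in an assay on isolated protein for inhibition of Amine oxidase [flavin-containing] A (Homo sapiens), read by spectrophotometry; on this read-out higher numbers stand for weaker inhibition and lower numbers for stronger inhibition:
compound 1 `COc1ccc(/C=N/Nc2nc3ccccc3nc2Cc2ccccc2)cc1OC` — 56 nM
compound 2 `COc1cc(/C(C)=N/Nc2nc3ccccc3nc2Cc2ccccc2)cc(OC)c1OC` — 29 nM

Compound 1 gives the higher of the two numbers, and its nearest neighbour is compound 2; the gap between the two is within the usual scatter of repeated measurements, so no order between them can be read from these values. Going by the values given here, no pair differing in a single place has been measured, so the size of a single change on this read-out is not yet known from the series itself.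

Compound 3 `Clc1ccccc1/C=N/Nc1nc2ccccc2nc1Cc1ccccc1` is the next compound to be measured. It differs from compound 1 by 2-chlorophenyl in place of 3,4-dimethoxyphenyl on a carbon with a double bond to nitrogen. Both of the hydrogen-bond acceptors carried by the leaving group are lost and nothing of that kind is gained.

For compound 3 a step of a 1.6-fold higher number from compound 1 to compound 3 (0.21 log units; within the scatter) is expected, toward a somewhat higher number but not clearly beyond the scatter. The estimate for compound 3 is 90 nM, with a range from 30 nM to 300 nM.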

Compound 3, half-maximal inhibitory concentration: 5.8 nM
For compound 3 the middle estimate is 16-fold (1.19 log units) above the measured one; the whole stated range lies above it.
By their numbers in this assay, from the lowest: compound 3; then compounds 2 and 1 (each within the scatter of the next).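

In this assay, the group on the carbon with a double bond to nitrogen clearly affects the read-out: 2-chlorophenyl in place of 3,4-dimethoxyphenyl gives a 9.7-fold lower number from compound 1 to compound 3 (0.98 log units; beyond the scatter), the first single-place step available in the series. In this pair, the hydrogen-bond acceptors of 3,4-dimethoxyphenyl are not required for a low number, and the entering group with fewer heavy atoms is accommodated. Nothing available explains the size or direction of this step.

The step combines loss of both methoxy groups with gain of chlorine, so the contribution of each remains unresolved. Plain phenyl, 2-methoxyphenyl or 2-fluorophenyl at this place would help separate those contributions, while an aminophenyl group would test a different kind of substituent.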